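Hydroxy in place of methoxy on the phenol-bearing ring

The compounds below may be only part of what the source reports. "The series", "measured", "known", "first", "only" and "open" are said of these compounds alone.

The measured compounds are:
compound 1, `O=C(Nc1cccc(-n2cc(-c3ccncc3)c(-c3ccc(Cl)c(O)c3)n2)c1)Nc1cccc(C(F)(F)F)c1`, 20000 nM;
compound 2, `O=C(Nc1cccc(-n2cc(-c3ccncc3)c(-c3ccc(Cl)c(O)c3)n2)c1)Nc1ccc(Cl)c(Cl)c1`, 15000 nM;
compound 3, `COc1cc(-c2nn(-c3cccc(NC(=O)Nc4ccc(Cl)c(C(F)(F)F)c4)c3)cc2-c2ccncc2)ccc1Cl`, 2480 nM.

In a functional assay on SR cells (Homo sapiens) for inhibition, read by sulforhodamine B assay, with a stated time of 48 h (a lower number here means a stronger inhibitor of growth, a higher number a weaker inhibitor of growth), compound 3 gives the lowest number of the three; compound 2 comes nearest, and compound 1 lies furthest away, both beyond the scatter. Compound 4, `O=C(Nc1cccc(-n2cc(-c3ccncc3)c(-c3ccc(Cl)c(O)c3)n2)c1)Nc1ccc(Cl)c(C(F)(F)F)c1`, is not yet measured. It differs from compound 3 by one change: hydrogen in place of methyl on an oxygen on an aromatic ring, that is, methoxy to hydroxy, 4-chloro-3-methoxyphenyl to 4-chloro-3-hydroxyphenyl.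

Among the compounds with values here, no measured step covers this change. Within the data shown here, the one measured step, a 1.3-fold lower number from compound 1 to compound 2 (0.12 log units; within the scatter), alters the aryl group on the urea, not the oxygen, and does not bear on it. What the numbers do show is that compound 1 and compound 2, both carrying the hydroxy group, give weak inhibition, while compound 3, with the methoxy, gives a lower number; whether this comes from the oxygen substituent or from the aryl urea group cannot be separated on these three compounds. Compound 4 is therefore expected to land between these, with a step of a 3.2-fold higher number from compound 3 to compound 4 (0.51 log units; beyond the scatter) toward a higher number and a wide range. The estimate for compound 4 in this assay is 8000 nM, between 2500 nM and 25000 nM.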

Compound 4, concentration for total growth inhibition: 2520 nM
Estimate against measurement, compound 4: 3.2-fold (0.50 log units) above, and the stated range covers the measured number.
By their numbers in this assay, from the lowest: compounds 3 and 4 (each within the scatter of the next); then compounds 2 and 1 (each within the scatter of the next).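

In this assay, methoxy to hydroxy on the aromatic ring gives a 1.0-fold higher number from compound 3 to compound 4 (0.01 log units; within the scatter), so on this urea the oxygen substituent makes no difference beyond the scatter, and the hydroxy group alone does not account for the higher numbers of compound 1 and compound 2. With the hydroxy group held fixed, the difference lies on the aryl urea: trifluoromethyl in place of chloro on an aromatic carbon gives a 6.0-fold lower number from compound 2 to compound 4 (0.77 log units; beyond the scatter), and chloro in place of hydrogen on an aromatic carbon gives a 7.9-fold lower number from compound 1 to compound 4 (0.90 log units; beyond the scatter), both beyond the scatter. Nothing shown here explains these steps or the flat step at the oxygen.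

Going by these compounds, the methoxy group appears with only one aryl urea, so whether it would also match hydroxy on the 3,4-dichlorophenyl or 3-(trifluoromethyl)phenyl urea remains open. On these data alone, how an ethoxy group on this oxygen, or an amine in place of the hydroxy, would compare also remains open.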